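The source may report more compounds than this note shows. Statements on the series, on what has been measured and on what is new or still open speak of the compounds shown alone.

Series measured in a functional assay on Hep cells (Homo sapiens) for cytotoxicity, read by sulforhodamine B assay, with a stated time of 48 h; a lower number here means a stronger inhibitor, a higher number a weaker inhibitor:

- Compound 1 `C=CCOc1cc(Br)ccc1C(=O)c1cccnc1`: > 100000 nM (a limit)
- Compound 2 `O=C(c1cccnc1)c1cc(F)ccc1O`: 12000 nM
- Compound 3 `C=CCOc1ccc(C)cc1C(=O)c1cccnc1`: 72000 nM

Compound 1 reads > 100000 nM, and this is a limit of the assay, not a number. Within the data shown here, only two compounds therefore carry true numbers. Compound 2 at 12000 nM holds the lower of these. Compound 3 at 72000 nM lies higher, and that gap is beyond the usual scatter. Compound 2 is thus the best-placed starting point on the numbers available, although its inhibition is still modest on this scale.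

The next compound to be measured is compound 4 `O=C(c1cccnc1)c1cc(Br)ccc1O`. Relative to compound 2 it has bromo in place of fluoro on an aromatic carbon. The halogen sits para to the hydroxy group, and the rest of the structure stays the same.

Among the measured compounds shown here, no measured pair isolates a change of this kind, so the expectation rests on compound 2 at 12000 nM and on the small size of the swap. In this assay the expected step of a 1.2-fold lower number from compound 2 to compound 4 (0.08 log units; within the scatter) is small, with nothing expected beyond the scatter. A wide range is kept because the series offers so little direct evidence. For compound 4 the estimated value is 10000 nM, with an expected range from 3500 nM to 35000 nM.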

Compound 4, half-maximal inhibitory concentration: 29000 nM
Compound 4: the middle estimate sits 2.9-fold (0.46 log units) below what was measured, within the range that was stated.
By their numbers in this assay, from the lowest: compound 2; then compound 4; then compound 3. At a limit, above all of these: compound 1.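

In this assay, bromo in place of fluoro on an aromatic carbon para to a hydroxy group gives a 2.4-fold higher number from compound 2 to compound 4 (0.38 log units; beyond the scatter), so this position responds to the identity of the halogen, and fluoro gives the lower number of the two. Among these compounds, this is the first pair that differs in one place, and the earlier compounds offered no step from which to read such a change. Compound 1 carries a limit, not a number: the limit of > 100000 nM in this assay, at which 1 of the 4 values shown sits.

From the compounds shown here alone, with a single step between two halogens, no trend can be drawn at this position, and it remains open whether chloro, methyl, methoxy or an amine in the same place would read closer to compound 2, closer to compound 4 or apart from both. Also open is what the hydroxy group contributes to these values, as no pair shown isolates it from the rest of the structure.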